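Diethylsulfamoyl in Place of (2-Methoxyethyl)sulfamoyl: Compound 3

The source may report more compounds than this note shows. Statements on the series, on what has been measured and on what is new or still open speak of the compounds shown alone.

Measured so far:
Compound 1, `COCCNS(=O)(=O)c1ccc(C)c(C#Cc2cc(Cl)ccc2OCC(=O)O)c1`: 3.6 nM in an assay on CHO cells for displacement of a labelled ligand from prostaglandin D2 receptor 2 (Homo sapiens), read by scintillation counting; on this read-out higher numbers stand for weaker inhibition and lower numbers for stronger inhibition
Compound 2, `CS(=O)(=O)c1ccc(F)c(C#Cc2cc(Cl)ccc2OCC(=O)O)c1`: 3.3 nM in this assay

Compound 1 holds the higher of the two numbers in this assay, but its nearest neighbour, compound 2, sits within the usual scatter of this kind of measurement, so the two are not told apart. Compound 3, `CCN(CC)S(=O)(=O)c1ccc(C)c(C#Cc2cc(Cl)ccc2OCC(=O)O)c1`, has not yet been measured. It differs from compound 1 in one place: diethylamino in place of (2-methoxyethyl)amino on a sulfonyl sulfur. For the measured compounds named here, no pair of measured compounds shows this change, so nothing here tells how the sulfonyl substituent moves the number. The step from compound 1 to compound 3 is therefore expected to stay within the scatter, with no clear direction; the estimate is a 1.3-fold higher number from compound 1 to compound 3 (0.10 log units; within the scatter). Compound 3 is expected to give about 4.5 nM in this assay, with a likely range from 1.5 nM to 14 nM.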

Compound 3, inhibition constant: 3.4 nM
Compound 3: middle estimate off by 1.3-fold (0.12 log units), on the high side; low and high end bracket the measured number.
By their numbers in this assay, from the lowest: compounds 2, 3 and 1 (each within the scatter of the next).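

In this assay, for the compounds shown here, the first step at this position, diethylamino in place of (2-methoxyethyl)amino on a sulfonyl sulfur, gives a 1.1-fold lower number from compound 1 to compound 3 (0.02 log units; within the scatter). The two groups have the same number of heavy atoms, but the hydrogen-bond donor and acceptor of (2-methoxyethyl)amino are absent from diethylamino, and in this one pair that difference leaves the number within the scatter. Nothing measured here accounts for this result.

The compounds shown leave open whether a group of another kind on the sulfonyl sulfur, such as a carboxylic acid, an unsubstituted amine or a longer chain, would also stay within the scatter. With a single step at this position, they also leave open whether the same swap would give a similar result on a different core.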